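Halopyridinylmethyl thiourea series: compound 1 to compound 3

The source may hold more compounds than are shown below. What is called first, only, known or untested is meant among the compounds shown, and "the series" means these compounds.

compound 1 `Nc1ccccc1NC(=O)c1ccc(NC(=S)NCc2cncc(Br)c2)cc1` — 7500 nM
compound 2 `Nc1ccccc1NC(=O)c1ccc(NC(=O)NCc2ccc(F)nc2)cc1` — 13000 nM

Both compounds were run in a functional assay on HepG2 cells (Homo sapiens) for cytotoxicity, read by MTT assay, with a stated time of 72 h; a higher number here means a weaker inhibitor, a lower number a stronger inhibitor. Compound 1 gives 7500 nM and compound 2 gives 13000 nM. Compound 1 has the lowest of the two numbers, but its gap to compound 2 lies within the scatter, so no order between them is claimed.

Compound 3 `Nc1ccccc1NC(=O)c1ccc(NC(=S)NCc2ccc(Cl)nc2)cc1` has not yet been measured. It differs from compound 1 in one place: 6-chloropyridin-3-yl in place of 5-bromopyridin-3-yl on a saturated chain carbon bound to an amide-type nitrogen. Among the measured compounds shown here, no pair of measured compounds differing in one place exists in this set, so the size of such a swap has no precedent here. The change keeps the ring type and the same counted content, exchanging one halopyridinyl group for another. Nothing in the two measured values points to a shift beyond the scatter. The expected step of a 1.1-fold higher number from compound 1 to compound 3 (0.03 log units; within the scatter) is therefore small, in no particular direction, and within the scatter. Compound 3 is estimated at 8000 nM, with a range from 3500 nM to 18000 nM.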

Compound 3, half-maximal inhibitory concentration: 19000 nM
Compound 3: middle estimate off by 2.4-fold (0.38 log units), on the low side; the measured number lies above the stated range.
By their numbers in this assay, from the lowest: compounds 1, 2 and 3 (each within the scatter of the next, the first and the last beyond it).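

In this assay, among the compounds shown here, 6-chloropyridin-3-yl in place of 5-bromopyridin-3-yl on a saturated chain carbon bound to an amide-type nitrogen gives a 2.5-fold higher number from compound 1 to compound 3 (0.40 log units; beyond the scatter), the first one-place step in this set, modest but beyond the scatter. The two groups match in ring type and in every count, yet the number moves, so at this position halopyridinyl groups are not interchangeable in this assay. No measurement shown accounts for the step, and the identity of the halogen and its place on the ring change together.

Which of these two changes carries the step remains open; 5-chloropyridin-3-yl and 6-bromopyridin-3-yl would separate them. The compounds shown also leave open how an unsubstituted pyridin-3-yl group would compare with either halogenated group.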